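From methylamino to carbamoyl on a shared core

The source may report more compounds than this note shows. Statements on the series, on what has been measured and on what is new or still open speak of the compounds shown alone.

Measured in a toxicity assay on CCRF-CEM cells (Homo sapiens) for cytotoxicity; on this read-out higher numbers stand for lower toxicity in this test and lower numbers for higher toxicity in this test:
- compound 1 `COC(=O)c1cccc2c1nc(-c1c(F)cccc1F)n2Cc1c(F)cccc1F`: 57.7 uM
- compound 2 `Fc1cccc(F)c1Cn1c(-c2c(F)cccc2F)nc2c(Cl)cccc21`: 30.4 uM
- compound 3 `CNc1cccc2c1nc(-c1c(F)cccc1F)n2Cc1c(F)cccc1F`: 27.2 uM

Compound 3 gives 27.2 uM. Its nearest neighbour on the numbers is reached with a 1.1-fold lower number from compound 2 to compound 3 (0.05 log units; within the scatter), and its furthest with a 2.1-fold lower number from compound 1 to compound 3 (0.33 log units; beyond the scatter). The unmeasured compound 4 `NC(=O)c1cccc2c1nc(-c1c(F)cccc1F)n2Cc1c(F)cccc1F` carries carbamoyl in place of methylamino on an aromatic carbon. Going by the values given here, no measured step shows this exact exchange. The three steps in hand all exchange groups at this same place, and the remaining one is a 1.9-fold lower number from compound 1 to compound 2 (0.28 log units; within the scatter). All three are small, so the measured steps give no sign of a large move. Like compound 4, compound 1 carries a carbonyl on that aromatic carbon and gives 57.7 uM, which leaves a slight upward drift possible. No step beyond the scatter is expected in this assay. The estimated change is a 1.4-fold higher number from compound 3 to compound 4 (0.15 log units; within the scatter). For compound 4 the expected value is 38 uM, within an estimated range of 17 uM to 85 uM.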

Compound 4, half-maximal toxic concentration: > 100 uM
Compound 4 gave a limit, no number; the forecaster's own chance of this, stated with the estimate: 10%; middle value at least 2.6-fold (0.42 log units) away from the limit.
By their numbers in this assay, from the lowest: compounds 3, 2 and 1 (each within the scatter of the next, the first and the last beyond it). At a limit, above all of these: compound 4.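

In this assay compound 4 stands at a limit of the assay and not at a number, > 100 uM, the only such value among the compounds shown: the limit of > 100 uM in this assay, at which 1 of the 4 values shown sits. Carbamoyl on this aromatic carbon therefore gives a step beyond the scatter against methylamino, an at least 3.6-fold higher number from compound 3 to compound 4 (0.56 log units; beyond the scatter), and against chloro, an at least 3.2-fold higher number from compound 2 to compound 4 (0.51 log units; beyond the scatter), whereas the exchanges among the earlier groups at this place gave only small steps. Against methoxycarbonyl the reading is less firm: amino in place of methoxy on the carbonyl carbon gives an at least 1.7-fold higher number from compound 1 to compound 4 (0.23 log units; that floor lies within the scatter), so this change may or may not separate the two compounds.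

As far as these compounds go, how far the true value of compound 4 lies past its limit remains open. So does whether a carboxylic acid or a methylcarbamoyl group on this aromatic carbon would also reach that limit.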